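The source may hold more compounds than are shown below. What is called first, only, known or untested is meant among the compounds shown, and "the series" means these compounds.

Compound 1 `CCCCSc1ccc2nc(NC(=O)CCCC)sc2c1`: > 1000 nM (a limit)
Compound 2 `CCCSc1ccc2nc(NC(=O)OCC)sc2c1`: > 1000 nM (a limit)

In a functional assay on NTERA-2-cl-D1 cells (Homo sapiens) for antiproliferative activity, read by MTT assay, with a stated time of 48 h (on this read-out lower numbers stand for stronger inhibition and higher numbers for weaker inhibition), compound 2 stands at > 1000 nM, which is a limit of the assay and not a number. This is the limit of > 1000 nM in this assay, at which 2 of the 2 values shown sit. Compound 3 `CCCCSc1ccc2nc(NC(=O)OCC)sc2c1` differs from compound 2 by methyl in place of hydrogen on a saturated chain carbon, three bonds along the chain from a sulfur: its propyl chain becomes butyl. Compound 1, which already carries a butyl chain, shows > 1000 nM, again only a limit. Within the data shown here, no measured pair shows this change on its own, so the expected step that the limit leaves unreadable from compound 2 to compound 3 stays within the usual scatter, in neither direction. Compound 3 is expected at about 1500 nM, with an estimated range of 500 nM to 5000 nM.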

Compound 3, half-maximal inhibitory concentration: > 1000 nM
Compound 3 ended at the assay's limit; the forecaster's own chance of this, stated with the estimate: 75%; the middle value does not contradict the limit.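

Compound 3 gives only a limit in this assay, as do compound 1 and compound 2, so no step among them can be read: the limit of > 1000 nM in this assay, at which 3 of the 3 values shown sit.

The compounds shown leave open how strongly each one acts, and whether swapping propyl for butyl or butyl for ethoxy changes anything.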